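The compounds below may be only part of what the source reports. "The series", "measured", "known", "first", "only" and "open" are said of these compounds alone.

Compound 1 `FC(F)(F)c1cccc(NC(=S)NCc2ccco2)c1` in an ADME assay on MDBK cells (Bos taurus) for cytotoxicity, read by MTT assay, with a stated time of 96 h (on this read-out lower numbers stand for higher toxicity in this test and higher numbers for lower toxicity in this test), gives > 100000 nM, a limit of the assay.
Compound 2 `FC(F)(F)c1cccc(NC(=S)Nc2ccccc2Br)c1` in this assay gives > 100000 nM, again a limit.
Compound 3 `CC(=O)NC(=S)Nc1cccc(C(F)(F)F)c1` in this assay gives > 100000 nM, once more a limit.

Compound 3 thus stands at the limit, and so do the two other compounds: all three sit at the limit of > 100000 nM in this assay, at which 3 of the 3 values shown sit. Compound 4 `CSCCCNC(=S)Nc1cccc(C(F)(F)F)c1` differs from compound 3 by 3-(methylsulfanyl)propyl in place of acetyl on an amide-type nitrogen. The measured steps that touch the same amide-type nitrogen, a step that the two limits leave unreadable from compound 1 to compound 3, a step that the two limits leave unreadable from compound 2 to compound 3 and a step that the two limits leave unreadable from compound 1 to compound 2, are all unreadable, so no size can be drawn from them. Across this change a step within the scatter is expected, a number no higher from compound 3 to compound 4 (the limit leaves the size open). Compound 4 is accordingly estimated at 100000 nM, between 50000 nM and 300000 nM, and most probably reported again only as a limit.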

Compound 4, half-maximal cytotoxic concentration: > 100000 nM
Compound 4: a limit, no number; the forecaster's own chance of this, stated with the estimate: 80%; the middle value lies on the limit itself.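

Compound 4 also stands at a limit, so its steps to compound 1, compound 2 and compound 3 cannot be read: the limit of > 100000 nM in this assay, at which 4 of the 4 values shown sit. In this assay the compounds shown leave open what size, if any, a change on the amide-type nitrogen has.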